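The source may hold more compounds than are shown below. What is called first, only, known or untested is meant among the compounds shown, and "the series" means these compounds.

In an assay on membranes from brain (strain Dunkin) for displacement of a labelled ligand from Sigma non-opioid intracellular receptor 1 (Cavia porcellus) (a higher number here means a weaker inhibitor, a lower number a stronger inhibitor), compound 1 `COc1cccc2c1CCCC2CCCC1CCN(C2CCCCC2)CC1` gives 1.1 nM. Compound 3 `COc1cccc2c1CCCC2CCCN1CCNCC1` gives 218 nM in this assay. Of the two actual numbers recorded so far, compound 3 holds the higher one, and its gap to the lower number of compound 1 lies well beyond the usual scatter. Compound 2 `COc1cccc2c1CCCC2CCC[N+]1(C)CC[N+](C)(C2CCCCC2)CC1` does not give a number at all in this assay but only a limit of the assay, > 5000 nM. That value of compound 2 sits at the limit of > 5000 nM in this assay, at which 1 of the 3 values shown sits, and is therefore not a number to be ranked against the others.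

Compound 4 `COc1cccc2c1CCCC2CCCN1CCN(C(=O)C2CCCCC2)CC1` has not yet been measured. It differs from compound 3 in a single place: cyclohexylcarbonyl in place of hydrogen on an amine nitrogen in a ring. Going by the values given here, no measured pair in this set shares that change, so the size of the step is open. The step from compound 3 to compound 4 is expected to be modest, leaning toward a higher number, a 1.8-fold higher number from compound 3 to compound 4 (0.26 log units; within the scatter). Compound 4 is accordingly expected to give about 400 nM in this assay, within a range from 60 nM to 3000 nM.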

Compound 4, inhibition constant: > 5000 nM
Compound 4 gave a limit, no number (the forecaster's own chance of this, stated with the estimate: 10%); middle value at least 12-fold (1.09 log units) from the limit.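

In this assay, going by these compounds alone, cyclohexylcarbonyl in place of hydrogen on this amine nitrogen in a ring gives an at least 22-fold higher number from compound 3 to compound 4 (1.36 log units; beyond the scatter), the first step that can be read at this position. Within the data shown here, it shows that this position does not accept this group without a large loss of binding, a loss that the earlier compounds could not reveal. Compound 4 gives only a limit and not a number, so the full size of the step stays unknown: the limit of > 5000 nM in this assay, at which 2 of the 4 values shown sit.

The change brings in the carbonyl and the cyclohexane ring together, so the compounds shown cannot tell which part matters. From the compounds shown here alone, a cyclohexylmethyl group on this nitrogen would keep the ring without the carbonyl, and an acetyl group would keep the carbonyl without the ring, so both remain open.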